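Chloro Fused Ring and Trifluoroethyl Swap on a Cyclase Activator

A few compounds are considered here, and "the series" means these few. Any claim that something is new, unique, unknown or untested is made for them only; others in the source may bear on it.

Compound 1, `CC1(C)C(=O)Nc2nc(-n3nc(Cc4c(F)ccc(F)c4F)c4ccccc43)nc(N)c21`: 2000 nM in an assay on CHO cells for activation of soluble guanylate cyclase alpha1/beta1 complex (Homo sapiens), read by cGMP accumulation; a higher number here means that more compound is needed for the effect, a lower number that less compound is needed.
Compound 2, `CC1(C)C(=O)Nc2nc(-n3nc(CCC(F)(F)F)c4ccccc43)nc(N)c21`: 882000 nM in this assay.
Compound 3, `CC1(C)C(=O)Nc2nc(-n3nc(Cc4c(F)ccc(F)c4F)c4cc(Cl)ccc43)nc(N)c21`: 7300 nM in this assay.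

Compound 4, `CC1(C)C(=O)Nc2nc(-n3nc(CCC(F)(F)F)c4cc(Cl)ccc43)nc(N)c21`, has not been measured. Compound 3 differs from compound 1 by chloro in place of hydrogen on an aromatic carbon, giving a 3.7-fold higher number from compound 1 to compound 3 (0.56 log units; beyond the scatter). The change from compound 1 to compound 2 is 2,2,2-trifluoroethyl in place of 2,3,6-trifluorophenyl on a saturated chain carbon bound to an aromatic carbon, and it produced a 440-fold higher number from compound 1 to compound 2 (2.64 log units; beyond the scatter). The change from compound 3 to compound 4 is 2,2,2-trifluoroethyl in place of 2,3,6-trifluorophenyl on a saturated chain carbon bound to an aromatic carbon, the same change at the same place on the chloro-bearing core. Because the first instance gave a 440-fold higher number from compound 1 to compound 2 (2.64 log units; beyond the scatter), the same change is expected to lift the number of compound 4 far above that of compound 3, so a 410-fold higher number from compound 3 to compound 4 (2.61 log units; beyond the scatter) is estimated. Compound 4 is therefore expected to give about 3000000 nM, within 700000 nM to 12000000 nM.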

Compound 4, half-maximal effective concentration: 87000 nM
Compound 4: the middle estimate sits 34-fold (1.54 log units) above what was measured; the whole stated range lies above it.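

Replacing 2,3,6-trifluorophenyl with 2,2,2-trifluoroethyl gave a 12-fold higher number from compound 3 to compound 4 (1.08 log units; beyond the scatter) on the chloro-bearing core, the same direction as on the core of compound 1 but not the same size: the same change on two cores in this assay, a 440-fold higher number (2.64 log units; beyond the scatter) from compound 1 to compound 2 and a 12-fold higher number (1.08 log units; beyond the scatter) from compound 3 to compound 4, 37-fold (1.57 log units) apart, beyond the scatter of two such steps
Chloro in place of hydrogen changed direction between the cores, giving a 10-fold lower number from compound 2 to compound 4 (1.01 log units; beyond the scatter): the same change on two cores in this assay, a 3.7-fold higher number (0.56 log units; beyond the scatter) from compound 1 to compound 3 and a 10-fold lower number (1.01 log units; beyond the scatter) from compound 2 to compound 4, 37-fold (1.57 log units) apart, beyond the scatter of two such steps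
Both comparisons rest on the same four compounds in this assay, so they show that neither change carried over in size within this set, but they do not show why or whether this extends to other groups.

On these data alone, whether a fluoro or methoxy group on the same aromatic carbon would follow the chloro result remains open. So does the outcome with an unsubstituted phenyl or a longer fluorine-free chain in place of 2,3,6-trifluorophenyl.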